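The source may report more compounds than this note shows. Statements on the series, on what has been measured and on what is new or still open speak of the compounds shown alone.

Compound 1 `CN1CCC/C1=N\C(=O)Nc1ccccc1` — 15 mg/kg
Compound 2 `CN1CCC/C1=N\C(=O)Nc1cccc(Cl)c1` — 15 mg/kg
Compound 3 `CN1CCC/C1=N\C(=O)Nc1cccc(C(F)(F)F)c1` — > 25 mg/kg

Going by the values given here, in a functional assay on the whole organism with Rattus norvegicus as the target, with a stated time of 5 days (a lower number here means that less compound is needed, a higher number that more compound is needed for the effect), compound 3 gives only a limit, > 25 mg/kg, not a number, so it is known only that more compound than that would be needed; this is the limit of > 25 mg/kg in this assay, at which 1 of the 3 values shown sits. Compound 4 `Cc1cccc(NC(=O)/N=C2\CCCN2C)c1` differs from compound 3 in one place: methyl in place of trifluoromethyl on an aromatic carbon.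

Among the compounds with values here, three measured steps bear on this. The step of no change at the digits printed from compound 1 to compound 2 (within the scatter) shows that chloro in place of hydrogen left the minimum effective dose unchanged within the scatter. The steps of an at least 1.6-fold higher number from compound 1 to compound 3 (0.22 log units; that floor lies within the scatter) and an at least 1.6-fold higher number from compound 2 to compound 3 (0.22 log units; that floor lies within the scatter) show that trifluoromethyl pushed the dose to the limit, though the floor of each step lies within the scatter. Replacing trifluoromethyl by methyl, a smaller group by atom count, is therefore expected to bring compound 4 back toward the doses of compound 1 and compound 2, a step of about an at least 1.3-fold lower number from compound 3 to compound 4 (0.14 log units; that floor lies within the scatter). The expected value for compound 4 is 18 mg/kg, with a range from 10 mg/kg to 35 mg/kg.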

Compound 4, minimum effective dose: 25 mg/kg
Compound 4: middle estimate off by 1.4-fold (0.14 log units), on the low side; the measured number falls inside the stated range.
By their numbers in this assay, from the lowest: compounds 1, 2 and 4 (each within the scatter of the next).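

In this assay, methyl on this aromatic carbon gives a 1.7-fold higher number from compound 1 to compound 4 (0.22 log units; within the scatter) and a 1.7-fold higher number from compound 2 to compound 4 (0.22 log units; within the scatter), so hydrogen, chloro and methyl at this position cannot be told apart. Among the four compounds, compound 3, with trifluoromethyl, is the only one that gives a limit and not a number. Methyl in place of trifluoromethyl gives a number no higher from compound 3 to compound 4 (the limit leaves the size open). The size of this step cannot be read, because compound 3 has no number to measure it from: the limit of > 25 mg/kg in this assay, at which 1 of the 4 values shown sits.

The compounds shown leave open whether an amine, a carboxylic acid or a longer chain at this position would keep the dose in the same range as hydrogen, chloro and methyl. They also leave open whether methyl or chloro would give the same result on another carbon of the six-membered aromatic ring.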